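The source may hold more compounds than are shown below. What is called first, only, known or untested is meant among the compounds shown, and "the series" means these compounds.

Among the measured compounds shown here, compound 2 `CCN(CC)c1oc2cc(OC)ccc2c(=O)c1Cc1c(OC(C)=O)ccc2ccc(=O)oc12` is one of two compounds measured in an ADME assay on MT4 cells (Homo sapiens) for cytotoxicity, read by MTT assay, with a stated time of 96 h; a higher number here means that more compound is tolerated, a lower number that less compound is tolerated. In this assay compound 2 gives 83000 nM, the only number shown for this series. Compound 1 `COc1ccc2c(=O)c(Cc3c(OC(C)=O)ccc4ccc(=O)oc34)c(N3CCCC3)oc2c1` differs from it in one place. In this assay compound 1 gives > 100000 nM, which is a limit of the assay rather than a number. Going from compound 1 to compound 2 the change is an at least 1.2-fold lower number from compound 1 to compound 2 (0.08 log units; that floor lies within the scatter), with the caveat of the limit of > 100000 nM in this assay, at which 1 of the 2 values shown sits, so the true size of that step is not settled.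

Compound 3 `COc1ccc2c(=O)c(Cc3c(OC(C)=O)ccc4ccc(=O)oc34)c(N(C)C)oc2c1` is not yet measured. It differs from compound 2 by dimethylamino in place of diethylamino on an aromatic carbon. For the measured compounds named here, the only step that bears on this change is the one from compound 1 to compound 2, where pyrrolidin-1-yl gave way to diethylamino, and that step sat within the scatter. The present change shortens the amine further, and no shown step separates compounds with such a difference beyond the scatter. Compound 3 is therefore expected to show a 1.1-fold higher number from compound 2 to compound 3 (0.04 log units; within the scatter), essentially no change beyond the scatter. Compound 3 is estimated at 90000 nM in this assay, between 40000 nM and 200000 nM.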

Compound 3, half-maximal cytotoxic concentration: 26000 nM
Compound 3: the middle estimate sits 3.5-fold (0.54 log units) above what was measured, outside the stated range (below it).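

In this assay, among the compounds shown here, the swap of diethylamino for dimethylamino on this aromatic carbon, next to the ring oxygen and ortho to a large group, is the first change at this position to reach beyond the scatter, with a 3.2-fold lower number from compound 2 to compound 3 (0.50 log units; beyond the scatter) and so a clear sensitivity to the amine here. The dimethylamino compound also separates from the pyrrolidin-1-yl compound, with an at least 3.8-fold lower number from compound 1 to compound 3 (0.58 log units; beyond the scatter), which makes compound 3 the one of the three that tolerates least compound in this test. Compound 1 stands at a limit rather than a number, so that second step is a floor only: the limit of > 100000 nM in this assay, at which 1 of the 3 values shown sits.

Going by these compounds, whether the number keeps falling with a still smaller amine on this carbon, such as methylamino or the plain amino group, or climbs with a longer chain such as dipropylamino, remains open. Also open, on these data alone, is where other ring amines, such as piperidin-1-yl or morpholin-4-yl, would fall relative to pyrrolidin-1-yl, and whether the sensitivity seen here would hold for these amines on a different group at the other positions of the shared core.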